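The compounds below may be only part of what the source reports. "The series", "measured", "known", "first", "only" and "open" are said of these compounds alone.

Two related compounds have been tested so far in a functional assay on Caco-2 cells (Homo sapiens) for inhibition, read by sulforhodamine B assay, with a stated time of 48 h; a lower number here means a stronger inhibitor, a higher number a weaker inhibitor. Compound 1 `COC(=O)[C@@]1(C)C[C@@H](c2coc3ccc(Br)cc3c2=O)N(c2ccccc2)O1` gives > 60000 nM, which is a limit of the assay and not a number. Compound 2 `COC(=O)[C@H]1C[C@@H](c2coc3ccccc3c2=O)N(c2ccccc2)O1` gives > 60000 nM, which is also a limit. Compound 2 therefore has no exact value, and both results sit at the same limit: the limit of > 60000 nM in this assay, at which 2 of the 2 values shown sit.

The next step leads to compound 3 `CCO[C@H]1C[C@@H](c2coc3ccccc3c2=O)N(c2ccccc2)O1`, with ethoxy in place of methoxycarbonyl on a saturated ring carbon. Among the measured compounds shown here, no measured pair shows what a single change does in this assay, so the expectation rests on compound 2 and its limit of > 60000 nM. The expected result is no step beyond the usual scatter, written as a number no higher from compound 2 to compound 3 (the limit leaves the size open). For compound 3 the estimated value is 60000 nM, with an expected range from 20000 nM to 100000 nM.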

Compound 3, half-maximal inhibitory concentration: > 60000 nM
Compound 3: no number, only a limit (the forecaster's own chance of this, stated with the estimate: 65%); the middle value lies on the limit itself.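

In this assay, among the compounds shown here, compound 3 ends at a limit and not at a number, as compound 2 does, so no step between compound 2 and compound 3 can be read: the limit of > 60000 nM in this assay, at which 3 of the 3 values shown sit. The compounds shown leave open how weak each one really is, and whether any change to the shared core would give a measurable value.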